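Trifluoromethyl on the Unvaried Ring of Compound 1

The source may hold more compounds than are shown below. What is called first, only, known or untested is meant among the compounds shown, and "the series" means these compounds.

Compound 1 `COc1ccc(-c2nnc(NC(=O)/C=C/c3ccccc3)s2)cc1` gives 0.68 ug/mL in a functional assay on A549 cells (Homo sapiens) for antiproliferative activity, read by MTT assay, with a stated time of 48 h (a higher number here means a weaker inhibitor, a lower number a stronger inhibitor), and stands lowest of the three measured numbers, with both other compounds beyond the scatter above it. Compound 2 `O=C(/C=C/c1ccccc1)Nc1nnc(-c2ccc(Cl)cc2)s1` gives 2.02 ug/mL and compound 3 `Cc1ccc(-c2nnc(NC(=O)/C=C/c3ccccc3)s2)cc1` gives 1.38 ug/mL in this assay. All measured steps concern the ring that carries the methoxy of compound 1: a 3.0-fold higher number from compound 1 to compound 2 (0.47 log units; beyond the scatter), a 2.0-fold higher number from compound 1 to compound 3 (0.31 log units; beyond the scatter), and a 1.5-fold lower number from compound 2 to compound 3 (0.17 log units; within the scatter).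

Compound 4 `COc1ccc(-c2nnc(NC(=O)/C=C/c3ccc(C(F)(F)F)cc3)s2)cc1` keeps the methoxy of compound 1 and differs from it in one place: trifluoromethyl in place of hydrogen on an aromatic carbon. Among the compounds with values here, the ring that receives the trifluoromethyl has not been varied among the measured compounds, so no measured step bears directly on this change; the steps that were measured on the other ring were modest at most. For compound 4 the expected step in this assay is a 1.3-fold higher number from compound 1 to compound 4 (0.12 log units; within the scatter), likely within the scatter. Compound 4 is estimated at 0.9 ug/mL, with a range from 0.35 ug/mL to 2.5 ug/mL.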

Compound 4, half-maximal inhibitory concentration: 0.69 ug/mL
Beside the measured number, compound 4's estimate is 1.3-fold (0.12 log units) above it; measured number inside the range.
By their numbers in this assay, from the lowest: compounds 1, 4, 3 and 2 (each within the scatter of the next, the first and the last beyond it).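

The ring that had stayed unvaried now has a measured step: in this assay there is a 1.0-fold higher number from compound 1 to compound 4 (0.01 log units; within the scatter) and so trifluoromethyl in place of hydrogen, para to a large group, leaves the number within the scatter of the parent. Four added heavy atoms at this position thus cost nothing measurable in this series, at least with methoxy on the other ring. No measurement shown here bears on why the number holds.

Going by these compounds, whether the same change stays within the scatter with the chloro of compound 2 or the methyl of compound 3 on the other ring remains open. Also open, on these data alone, is how this position responds to a group of another kind, such as an amine, a carboxylic acid or a longer chain.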